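Taking the carboxymethoxy group away from compound 3

This account rests on a few compounds, and the source may have more. Where it says the series, first, only, none or still open, it means among the compounds named here.

Measured in a physicochemical assay for solubility, at pH 7.4; on this read-out higher numbers stand for higher solubility and lower numbers for lower solubility:
Compound 1 `COCc1nc(Nc2ccc(C(F)(F)F)cc2)c2ccc(-c3ncccc3C(F)(F)F)cc2n1`: 0.2 ug/mL
Compound 2 `O=P(O)(O)OCc1nc(Nc2ccc(C(F)(F)F)cc2)c2ccc(-c3ncccc3C(F)(F)F)cc2n1`: > 138 ug/mL (a limit of the assay)
Compound 3 `O=C(O)COCc1nc(Nc2ccc(C(F)(F)F)cc2)c2ccc(-c3ncccc3C(F)(F)F)cc2n1`: 125 ug/mL

Of the two values that are true numbers, the higher belongs to compound 3, with 125 ug/mL. Against compound 2, whose value is only a limit, the comparison reads an at least 1.1-fold lower number from compound 2 to compound 3 (0.04 log units; that floor lies within the scatter).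

Compound 4 `OCCc1nc(Nc2ccc(C(F)(F)F)cc2)c2ccc(-c3ncccc3C(F)(F)F)cc2n1` differs from compound 3 by hydroxymethyl in place of carboxymethoxy on a saturated chain carbon bound to an aromatic carbon. In words, hydroxymethyl stands in place of carboxymethoxy on a saturated chain carbon bound to an aromatic carbon.

For the measured compounds named here, two measured steps bear on this. Adding the carboxy gave a 630-fold higher number from compound 1 to compound 3 (2.80 log units; beyond the scatter), and the other step was of like size, an at least 690-fold higher number from compound 1 to compound 2 (2.83 log units; beyond the scatter). Compound 4 carries no carboxy, so it is expected to fall back towards compound 1, which gave 0.2 ug/mL in this assay. The expected change is large and downward, a 250-fold lower number from compound 3 to compound 4 (2.40 log units; beyond the scatter). For compound 4 the estimate is 0.5 ug/mL, with an expected range of 0.1 ug/mL to 3 ug/mL.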

Compound 4, solubility: 0.02 ug/mL
The estimate for compound 4 lay 25-fold (1.40 log units) above the measured number, outside the stated range (below it).
By their numbers in this assay, from the lowest: compound 4; then compound 1; then compound 3. At a limit, above all of these: compound 2.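

The change from carboxymethoxy to hydroxymethyl on a saturated chain carbon bound to an aromatic carbon gave, in this assay, a 6300-fold lower number from compound 3 to compound 4 (3.80 log units; beyond the scatter), and the outcome did not stop at the level of the methoxy compound but went past it, a 10-fold lower number from compound 1 to compound 4 (1.00 log units; beyond the scatter). At this place, then, the read-out can fall under that of compound 1 as well as rise over it, and a hydroxymethyl group does not by itself lift it. Against compound 2 the step is only a floor, an at least 6900-fold lower number from compound 2 to compound 4 (3.83 log units; beyond the scatter), and the value of compound 2 is a limit, not a number: the limit of > 138 ug/mL in this assay, at which 1 of the 4 values shown sits.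

The compounds shown leave open whether an amine or a longer chain ending in hydroxy at this place would sit nearer compound 3 or compound 4. What lies behind the drop from compound 1 to compound 4 also stays unexplained by these data.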